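Swapping an amide for a methylated aromatic ring on the core

The compounds below may be only part of what the source reports. "The series", "measured", "known", "first", "only" and "open" are said of these compounds alone.

Measured compounds:
- Compound 1, `COc1ccc(Cl)cc1S(=O)(=O)Nc1cncc(-c2cccnc2)c1`: 73 nM
- Compound 2, `COc1ccc(Cl)cc1S(=O)(=O)Nc1cncc(-c2ccncc2)c1`: 73 nM
- Compound 3, `COc1ccc(Cl)cc1S(=O)(=O)Nc1cncc(C(N)=O)c1`: 16 nM

All three share one core and differ only in the group on an aromatic carbon of the six-membered ring with one nitrogen. In an assay on isolated protein for inhibition of alkaline phosphatase, tissue-nonspecific isozyme (Homo sapiens) (on this read-out higher numbers stand for weaker inhibition and lower numbers for stronger inhibition), compound 3 gives the lowest number of the three, and its distance from the other two is beyond the scatter in both cases: a 4.6-fold lower number from compound 1 to compound 3 (0.66 log units; beyond the scatter) and a 4.6-fold lower number from compound 2 to compound 3 (0.66 log units; beyond the scatter). The two pyridinyl compounds, compound 1 and compound 2, give numbers within the scatter of each other, no change at the digits printed from compound 1 to compound 2 (within the scatter).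

Compound 4, `COc1ccc(Cl)cc1S(=O)(=O)Nc1cncc(-c2ccccc2C)c1`, has not yet been measured. It differs from compound 3 in one place: 2-methylphenyl in place of carbamoyl on an aromatic carbon. This move runs opposite to the two measured steps, which replaced an aromatic ring by carbamoyl and lowered the number modestly. For the measured compounds named here, replacing carbamoyl by another aromatic ring is therefore expected to raise the number again, roughly back toward where compound 1 and compound 2 stand, though a ring of carbon only with a methyl group has no measured counterpart here. The expected step is a 5.6-fold higher number from compound 3 to compound 4 (0.75 log units; beyond the scatter). For compound 4 the estimate in this assay is 90 nM, in the range 35 nM to 250 nM.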

Compound 4, half-maximal inhibitory concentration: 178 nM
Beside the measured number, compound 4's estimate is 2.0-fold (0.30 log units) below it, and the stated range covers the measured number.
By their numbers in this assay, from the lowest: compound 3; then compounds 1 and 2 (each within the scatter of the next); then compound 4.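

In this assay the two pyridinyl rings could not be told apart, but this position does separate aromatic rings: the change to 2-methylphenyl gives a 2.4-fold higher number from compound 1 to compound 4 (0.39 log units; beyond the scatter) and also a 2.4-fold higher number from compound 2 to compound 4 (0.39 log units; beyond the scatter) for the other pyridinyl compound. Against carbamoyl the same ring gives an 11-fold higher number from compound 3 to compound 4 (1.05 log units; beyond the scatter) and this large step is wider than either step from carbamoyl to a pyridinyl ring. Among these four compounds, carbamoyl therefore holds the lowest number and 2-methylphenyl the highest, with the pyridinyl rings in the middle. On these data alone, what plain phenyl, a methyl amide or a carboxylic acid would give here stays open, so the methyl group and the ring of carbon only cannot be weighed separately. Nothing available explains these differences.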